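Bromo in Place of Fluoro and Cell Toxicity

This account rests on a few compounds, and the source may have more. Where it says the series, first, only, none or still open, it means among the compounds named here.

Compound 1 `COC(=O)c1ccc(NCc2cncn2Cc2cccc(Br)c2)cc1-c1ccccc1`: > 10000 nM
Compound 2 `COC(=O)c1ccc(NCc2cncn2Cc2cccc(F)c2)cc1-c1ccccc1`: > 1000 nM
Compound 3 `COC(=O)c1ccc(NCc2cncn2Cc2ccc(F)cc2)cc1-c1ccccc1`: "not determined" (no result reported)

Three compounds share one core, and two of them have been tested in a toxicity assay on NIH3T3 cells (Mus musculus) for cytotoxicity, read by resazurin assay; a lower number here means that less compound is needed, a higher number that more compound is needed for the effect. For compound 1 the value reported is only a limit of the assay, > 10000 nM. For compound 2 the value reported is likewise a limit, > 1000 nM. From the compounds shown here alone, compound 1 differs from compound 2 by bromo in place of fluoro on an aromatic carbon, and because both values are limits, at the limit of > 1000 nM in this assay, at which 1 of the 3 values shown sits, and at the limit of > 10000 nM in this assay, at which 1 of the 3 values shown sits, the step that the two limits leave unreadable from compound 2 to compound 1 cannot be read; its size stays open. Compound 3 differs from compound 2 in the core by 4-fluorophenyl in place of 3-fluorophenyl on a saturated chain carbon bound to an aromatic nitrogen, and for compound 3 this assay gave "not determined" (no result reported), no number at all.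

Compound 4 `COC(=O)c1ccc(NCc2cncn2Cc2ccc(Br)cc2)cc1-c1ccccc1` has not yet been measured. It differs from compound 3 by bromo in place of fluoro on an aromatic carbon, the same kind of change as that from compound 2 to compound 1, though the place differs: there the bromo sits meta to a large group, here it sits para to a large group. Among the measured compounds shown here, since compound 3 has no value, no step from compound 3 to compound 4 can be placed; what can be said rests on compound 1 with > 10000 nM and compound 2 with > 1000 nM, both limits, so a step from compound 3 to compound 4 is expected to remain unreadable in the same way. Compound 4 is therefore expected to show low toxicity in this assay, with an estimate of 20000 nM, between 5000 nM and 80000 nM.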

Compound 4, half-maximal effective concentration: > 10000 nM
Compound 4: no number, only a limit (the forecaster's own chance of this, stated with the estimate: 85%); the middle value is on the limit's open side.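

In this assay compound 4 gives > 10000 nM, which is a limit of the assay and not a number. Among the compounds shown here, compound 1 and compound 2 also carry only limits, so no step from either of them to compound 4 can be read. The compounds shown leave open where the actual half-maximal effective concentrations lie, and whether 4-bromophenyl in place of 3-bromophenyl or 3-fluorophenyl changes them at all.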